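This account rests on a few compounds, and the source may have more. Where it says the series, first, only, none or still open, it means among the compounds named here.

Compound 1 `COc1cc(C=C(C(=O)/C=C/c2cccc(OC)c2OC)C(=O)/C=C/c2cccc(OC)c2OC)ccc1O` and compound 2 `COc1ccc(C=C(C(=O)/C=C/c2cccc(OC)c2OC)C(=O)/C=C/c2cccc(OC)c2OC)cc1OC` share one core and differ by a single group: methyl in place of hydrogen on an oxygen on an aromatic ring. In a functional assay on A549 cells (Homo sapiens) for antiproliferative activity, read by sulforhodamine B assay, with a stated time of 48 h (a higher number here means a weaker inhibitor, a lower number a stronger inhibitor), compound 1 gives 130 nM, and compound 2 gives 170 nM, so that a 1.3-fold higher number from compound 1 to compound 2 (0.12 log units; within the scatter). Compound 3 `COc1ccc(OC)c(/C=C/C(=O)C(=Cc2ccc(O)c(OC)c2)C(=O)/C=C/c2cc(OC)ccc2OC)c1` has the same atoms as compound 1 joined differently; the difference between the two cores is not broken down here. In this assay compound 3 gives 190 nM, a number within the scatter of both compound 1 and compound 2. Compound 4 `COc1ccc(OC)c(/C=C/C(=O)C(=Cc2ccc(OC)c(OC)c2)C(=O)/C=C/c2cc(OC)ccc2OC)c1` is not yet measured. It differs from compound 3 in the way compound 2 differs from compound 1: methyl in place of hydrogen on an oxygen on an aromatic ring. Since the place of the change is described in the same words for both pairs, the change is the same one, and it occurs twice among the four compounds. The earlier step stayed within the scatter, so a step of similar size is expected here, a 1.3-fold higher number from compound 3 to compound 4 (0.10 log units; within the scatter), resting on a 1.3-fold higher number from compound 1 to compound 2 (0.12 log units; within the scatter) alone. Compound 4 is therefore estimated at 240 nM in this assay, with a likely span from 120 nM to 480 nM.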

Compound 4, half-maximal inhibitory concentration: 400 nM
Estimate against measurement, compound 4: 1.7-fold (0.22 log units) below, and the stated range covers the measured number.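

On the core of compound 3, methyl in place of hydrogen on the oxygen turns 4-hydroxy-3-methoxyphenyl into 3,4-dimethoxyphenyl and gives, in this assay, a 2.1-fold higher number from compound 3 to compound 4 (0.32 log units; beyond the scatter). Set beside the same change on the core of compound 1, this step cannot be told apart from the earlier one: the same change on two cores in this assay, a 1.3-fold higher number (0.12 log units; within the scatter) from compound 1 to compound 2 and a 2.1-fold higher number (0.32 log units; beyond the scatter) from compound 3 to compound 4, 1.6-fold (0.21 log units) apart, within the scatter of two such steps The change therefore carries across these two cores without a measurable dependence on the core, but two pairs do not fix its size, and they show nothing about any other core in the series.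

The compounds shown leave open how a group other than hydroxy or methoxy would read at this place, such as an ethoxy group, a longer alkoxy chain or an amine. They also leave open whether removing the methyl from a methoxy group on one of the other aromatic rings would give a step of similar size.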